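The compounds below may be only part of what the source reports. "The series", "measured", "known", "first", "only" and "open" are said of these compounds alone.

Measured compounds:
Compound 1 `OCc1ccc(-c2nn(Cc3ccccc3F)c3cnccc23)o1` — 6930 nM
Compound 2 `Cc1nc(-c2nn(Cc3ccccc3F)c3ncccc23)oc1CO` — 900 nM
Compound 3 `CC(C)(C)c1cnc(-c2nn(Cc3ccccc3F)c3ncccc23)nc1N` — 709000 nM

All three were tested in a functional assay (aorta) with Oryctolagus cuniculus as the target; a lower number here means a stronger inhibitor, a higher number a weaker inhibitor. Compound 3 gives the highest number of the three, and both gaps are far beyond the usual scatter: compound 1 sits a long way below it, and compound 2 further still, so compound 3 is clearly the weakest inhibitor of the set.

Compound 4 `CC(C#N)CCCCCc1cnc(-c2nn(Cc3ccccc3F)c3ncccc23)nc1N` has not yet been measured in this assay. It differs from compound 3 in one place: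

6-cyanoheptyl in place of tert-butyl on an aromatic carbon

For the measured compounds named here, no measured pair in this set changes the same position, so nothing in the data shows how this exchange shifts the read-out. The account therefore rests on the weak starting point of compound 3 alone. Compound 4 is expected to land near compound 3, with the step of a 2.4-fold lower number from compound 3 to compound 4 (0.37 log units; beyond the scatter) as a modest gain at best and a real chance of none beyond the scatter. For compound 4 the estimate is 300000 nM, within a range of 40000 nM to 2000000 nM.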

Compound 4, half-maximal inhibitory concentration: 1290000 nM
For compound 4 the middle estimate is 4.3-fold (0.63 log units) below the measured one, and the stated range covers the measured number.
By their numbers in this assay, from the lowest: compound 2; then compound 1; then compounds 3 and 4 (each within the scatter of the next).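

In this assay, putting 6-cyanoheptyl in place of tert-butyl on the aromatic carbon ortho to an amino group gives a 1.8-fold higher number from compound 3 to compound 4 (0.26 log units; within the scatter), so the two compounds cannot be told apart. For the compounds shown here, this is the first reading of any change at this position, and it shows that the larger group with its nitrile brings neither a gain nor a loss that stands clear of the scatter, leaving the number as high as it was. Nothing available here explains why the read-out stays put.

The compounds shown leave open whether any group at this position can move the number at all, for instance a methyl, a carboxylic acid or a chain ending in an amine. They also leave open whether the same exchange would stay as flat on the cores of the other compounds.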